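The compounds below may be only part of what the source reports. "The series", "measured", "known", "first", "only" and "open" are said of these compounds alone.

Compounds measured in a physicochemical assay for lipophilicity, using the shake flask method, in phosphate buffer, measured as octanol-water partition, with a stated time of 85 min, at pH 7.4; on this read-out higher numbers stand for higher lipophilicity and lower numbers for lower lipophilicity:
compound 1 `COc1ccc(-c2cn3ccnc3c(-c3ccc4ncn(C5CCCCC5)c4c3)n2)cc1` — 1.41
compound 2 `CCc1ccc(-c2cn3ccnc3c(-c3ccc4ncn(C5CCCCC5)c4c3)n2)cc1` — 1.66

Compound 1 stands lowest of the two in this assay; its nearest neighbour is compound 2, with a number 0.25 log units higher from compound 1 to compound 2 (within the scatter).

Compound 3 `FC(F)(F)c1cccc(-c2cn3ccnc3c(-c3ccc4ncn(C5CCCCC5)c4c3)n2)c1` is not yet measured. Relative to compound 1 the change is 3-(trifluoromethyl)phenyl in place of 4-methoxyphenyl on an aromatic carbon.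

For the measured compounds named here, the one measured step that bears on this, a number 0.25 log units higher from compound 1 to compound 2 (within the scatter), also removes the methoxy group and sits within the scatter. Going by the values given here, no measured step covers the trifluoromethyl group. A modest rise is therefore expected for compound 3, a number 0.49 log units higher from compound 1 to compound 3 (beyond the scatter), giving an estimate of 1.9 with a range from 1.5 to 2.4.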

Compound 3, partition coefficient: 1.72
Compound 3: middle estimate off by 0.18 log units, on the high side, within the range that was stated.
By their numbers in this assay, from the lowest: compounds 1, 2 and 3 (each within the scatter of the next, the first and the last beyond it).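

In this assay, for the compounds shown here, 3-(trifluoromethyl)phenyl in place of 4-methoxyphenyl gives the only step at this position that lies beyond the scatter (a number 0.31 log units higher from compound 1 to compound 3 (beyond the scatter)). In place of 4-ethylphenyl, the same group gives a step within the scatter (a number 0.06 log units higher from compound 2 to compound 3 (within the scatter)), so compound 2 and compound 3 cannot be told apart on this read-out. No evidence is available that accounts for either step.

Both steps exchange only aryl groups on this aromatic carbon. As far as these compounds go, how an amine or a carboxylic acid at the same place would read in this assay remains open.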